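The source may hold more compounds than are shown below. What is called first, only, known or untested is meant among the compounds shown, and "the series" means these compounds.

Compound 1 `Fc1ccc(Nc2nncc3ccccc23)cc1` gives 5.4 nM
Compound 2 `NS(=O)(=O)c1ccc(Nc2nncc3ccccc23)cc1` gives 14 nM

In a functional assay on OVCAR-3 cells (Homo sapiens) for antiproliferative activity, read by sulforhodamine B assay, with a stated time of 72 h (on this read-out lower numbers stand for stronger inhibition and higher numbers for weaker inhibition), compound 2 holds the higher of the two numbers. Compound 3 `N#Cc1ccc(Nc2nncc3ccccc23)cc1` has cyano in place of sulfamoyl on an aromatic carbon. Among the compounds with values here, the one measured step at this place is a 2.6-fold higher number from compound 1 to compound 2 (0.41 log units; beyond the scatter) and it was modest, with sulfamoyl in place of fluoro. A step of similar or smaller size, toward a lower number, is therefore expected in this assay as sulfamoyl leaves, and it may stay within the scatter. The expected step is a 1.8-fold lower number from compound 2 to compound 3 (0.24 log units; within the scatter) on this estimate. For compound 3 the estimated value is 8 nM with an expected range from 2.5 nM to 25 nM in this assay.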

Compound 3, half-maximal inhibitory concentration: 4.3 nM
Compound 3: middle estimate off by 1.9-fold (0.27 log units), on the high side; the range from low to high includes it.
By their numbers in this assay, from the lowest: compounds 3 and 1 (each within the scatter of the next); then compound 2.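

In this assay, replacing sulfamoyl with cyano gives a 3.3-fold lower number from compound 2 to compound 3 (0.51 log units; beyond the scatter), a step beyond the scatter. Cyano and fluoro, by contrast, are not separated at this position, with a 1.3-fold lower number from compound 1 to compound 3 (0.10 log units; within the scatter). Among these three groups on the aromatic carbon, only sulfamoyl stands apart, and it carries the higher number.

Nothing shown accounts for that difference. From the compounds shown here alone, it also remains open whether an amine, a carboxylic acid or a longer chain at this place would stay level with compound 1 or shift the number as sulfamoyl does.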